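The source may report more compounds than this note shows. Statements on the series, on what has been measured and on what is new or still open speak of the compounds shown alone.

Compound 1 `COc1ccc(NC(=S)N/N=C\c2ccnc3ccccc23)cc1`: 101000 nM
Compound 2 `Fc1ccc(NC(=S)N/N=C\c2ccnc3ccccc23)cc1`: 45900 nM
Compound 3 `S=C(N/N=C\c1ccnc2ccccc12)Nc1ccccc1`: 118000 nM

These three values come from an ADME assay on RAW264.7 cells (Mus musculus) for cytotoxicity, read by MTT assay, with a stated time of 48 h; on this read-out lower numbers stand for higher toxicity in this test and higher numbers for lower toxicity in this test. In this assay compound 3 gives 118000 nM. The measurements show a 1.2-fold higher number from compound 1 to compound 3 (0.07 log units; within the scatter), and they also show a 2.6-fold higher number from compound 2 to compound 3 (0.41 log units; beyond the scatter), so only the second of these gaps is a clear separation.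

Compound 4 `S=C(N/N=C\c1ccnc2ccccc12)Nc1ccc(Cl)cc1` has chloro in place of hydrogen on an aromatic carbon, para to a large group: chloro in place of hydrogen on an aromatic carbon. Among the measured compounds shown here, no chloro compound has yet been measured, so the evidence is indirect. The closest comparison is compound 2, which has fluoro at that place and which, read in reverse, sits modestly lower: a 2.6-fold higher number from compound 2 to compound 3 (0.41 log units; beyond the scatter). The methoxy comparison with compound 1 shows no shift beyond the scatter: a 1.2-fold higher number from compound 1 to compound 3 (0.07 log units; within the scatter). With only these two substitutions to go on, a modest fall in this assay is expected, of about the size seen with compound 2, although a result within the scatter would not be surprising. The expected change is a 2.3-fold lower number from compound 3 to compound 4 (0.36 log units; beyond the scatter). Compound 4 is estimated at 52000 nM, with an expected range of 22000 nM to 115000 nM.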

Compound 4, half-maximal cytotoxic concentration: 63500 nM
The estimate for compound 4 lay 1.2-fold (0.09 log units) below the measured number; low and high end bracket the measured number.
By their numbers in this assay, from the lowest: compounds 2, 4, 1 and 3 (each within the scatter of the next, the first and the last beyond it).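

In this assay, chloro in place of hydrogen, para to a large group, gives a step that stays within the scatter (for this change, a 1.9-fold lower number from compound 3 to compound 4 (0.27 log units; within the scatter)), and compound 4 likewise cannot be told apart from the two other substituted compounds (a 1.4-fold higher number from compound 2 to compound 4 (0.14 log units; within the scatter); a 1.6-fold lower number from compound 1 to compound 4 (0.20 log units; within the scatter)). Among the compounds shown here, this is what the earlier compounds did not show: compound 4 lies within the scatter of both compound 2 and compound 3 even though those two stand clearly apart, so the chloro compound does not settle on either side of that gap, and the only clear separations among the four remain the two that involve compound 2 (a 2.2-fold lower number from compound 1 to compound 2 (0.34 log units; beyond the scatter); a 2.6-fold higher number from compound 2 to compound 3 (0.41 log units; beyond the scatter)).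

The compounds shown carry only hydrogen, fluoro, chloro or methoxy at this position, so it remains open how an amine, a carboxylic acid or a longer chain would read there. From the compounds shown here alone, it is also open whether bromo or trifluoromethyl would stand apart from hydrogen as fluoro does or stay within the scatter as chloro does, and nothing at hand accounts for any of these numbers.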